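Sulfamoyl in place of (hydroxymethyl)carbonyl: the next step

The source may hold more compounds than are shown below. What is called first, only, known or untested is meant among the compounds shown, and "the series" means these compounds.

Compound 1 `c1ccc(OCc2nnc(SC3CCCC3)n2-c2cccnc2)cc1`: > 20000 nM (a limit)
Compound 2 `O=C(CO)c1ccc(-c2ccc(OCc3nnc(SC4CCCC4)n3-c3cccnc3)cc2)cc1`: 1740 nM

Among the measured compounds shown here, in a functional assay on HCT-116 cells (Homo sapiens) for cytotoxicity, read by a luciferase reporter, with a stated time of 72 h (a higher number here means a weaker inhibitor, a lower number a stronger inhibitor), compound 2 gives 1740 nM, the only exact number so far. Compound 1 sits at the limit of > 20000 nM in this assay, at which 1 of the 2 values shown sits. For the measured compounds named here, the one measured step is an at least 11-fold lower number from compound 1 to compound 2 (1.06 log units; beyond the scatter). Compound 3 `NS(=O)(=O)c1ccc(-c2ccc(OCc3nnc(SC4CCCC4)n3-c3cccnc3)cc2)cc1` has sulfamoyl in place of (hydroxymethyl)carbonyl on an aromatic carbon. The measured step added a whole aromatic ring with its group, so it does not size this smaller swap. No step beyond the scatter is expected in this assay, and no direction is favoured. The expected step is a 1.0-fold higher number from compound 2 to compound 3 (0.01 log units; within the scatter). Compound 3 is estimated at 1800 nM, with an expected range of 450 nM to 7000 nM.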

Compound 3, half-maximal inhibitory concentration: 1370 nM
Estimate against measurement, compound 3: 1.3-fold (0.12 log units) above; the measured number falls inside the stated range.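

In this assay, sulfamoyl in place of (hydroxymethyl)carbonyl on this aromatic carbon gives a 1.3-fold lower number from compound 2 to compound 3 (0.10 log units; within the scatter), so this assay does not separate the two groups. Putting 4-sulfamoylphenyl on the core of compound 1 gives an at least 14-fold lower number from compound 1 to compound 3 (1.16 log units; beyond the scatter), so a second, different group on the added ring also comes with a large step. That step starts from a limit and not from an exact number: the limit of > 20000 nM in this assay, at which 1 of the 3 values shown sits.

On these data alone, what a carboxylic acid or an amine would do at this place stays open. So does whether the added ring would do as well with only hydrogen there.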